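Amide nitrogen substituent: cyclohexyl to phenyl

The source may hold more compounds than are shown below. What is called first, only, known or untested is meant among the compounds shown, and "the series" means these compounds.

Compound 1 `O=C(Cn1cc(CN2C(=O)C(=O)c3c(Cl)ccc(Cl)c32)nn1)OC1CCCCC1` and compound 2 `O=C(Cn1cc(CN2C(=O)C(=O)c3c(Cl)ccc(Cl)c32)nn1)NC1CCCCC1` share one core and differ only at the carbonyl carbon. In a functional assay on SW780 cells (Homo sapiens) for inhibition, read by CCK-8 assay, with a stated time of 72 h (a lower number here means a stronger inhibitor, a higher number a weaker inhibitor), compound 1 gives 25200 nM and compound 2 gives 93300 nM. The step of a 3.7-fold higher number from compound 1 to compound 2 (0.57 log units; beyond the scatter) is the only measured one in the set. For compound 3 `O=C1C(=O)N(Cc2cn(CC(=O)N3CCNCC3)nn2)c2c(Cl)ccc(Cl)c21` the result reads "nd(insoluble)" (no result reported), so no number exists for it. On the numbers shown, compound 2 stands at the higher of the two numbers, its nearest neighbour being compound 1 at a distance beyond the scatter.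

Compound 4 `O=C(Cn1cc(CN2C(=O)C(=O)c3c(Cl)ccc(Cl)c32)nn1)Nc1ccccc1` differs from compound 2 by phenyl in place of cyclohexyl on an amide-type nitrogen. Among the measured compounds shown here, no measured step exchanges a non-aromatic ring for an aromatic one; the step from compound 1 to compound 2 changed the atom linking the ring to the carbonyl and left the ring itself untouched, so it does not bear on this change. With nothing to indicate a direction, the expected step of a 1.0-fold lower number from compound 2 to compound 4 (0.02 log units; within the scatter) is none beyond the scatter. Compound 4 is therefore estimated at 90000 nM, with a range from 30000 nM to 270000 nM.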

Compound 4, half-maximal inhibitory concentration: 27000 nM
Compound 4: middle estimate off by 3.3-fold (0.52 log units), on the high side; the whole stated range lies above it.
By their numbers in this assay, from the lowest: compounds 1 and 4 (each within the scatter of the next); then compound 2.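

In this assay, the ring on the amide-type nitrogen affects the result: a 3.5-fold lower number from compound 2 to compound 4 (0.54 log units; beyond the scatter), and the two groups differ in what is counted here only in that phenyl is aromatic. Anilino and cyclohexyloxy on the carbonyl carbon give values within the scatter of each other, a 1.1-fold higher number from compound 1 to compound 4 (0.03 log units; within the scatter), so the rise seen with a 3.7-fold higher number from compound 1 to compound 2 (0.57 log units; beyond the scatter) does not extend to every amide-type nitrogen at this carbonyl; it holds for cyclohexylamino and goes against anilino. Nothing measured here explains why the phenyl ring differs from the cyclohexyl ring at this place.

Still open, as far as these compounds go, is whether a phenyl ring carrying a methoxy group or a chlorine would move the value further from that of compound 4. A benzylamino group would show whether a methylene spacer between the amide-type nitrogen and the phenyl ring keeps the value of compound 4, and a phenyl ester would show whether the linking atom matters with an aromatic ring.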